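From compound 3 to compound 4: a group removed

A few compounds are considered here, and "the series" means these few. Any claim that something is new, unique, unknown or untested is made for them only; others in the source may bear on it.

In a functional assay on KB cells (Homo sapiens) for antiproliferative activity, read by sulforhodamine B assay, with a stated time of 48 h (a higher number here means a weaker inhibitor of growth, a lower number a stronger inhibitor of growth), the values stand as follows:

- Compound 1 `COc1ccc(S(=O)(=O)Nc2ccc(CCc3ccc(C(=O)Nc4ccccc4N)cc3)cc2)cc1` gives > 10000 nM as a limit of the assay
- Compound 2 `COc1ccc(S(=O)(=O)Nc2cccc(CCc3ccc(C(=O)Nc4ccccc4N)cc3)c2)cc1` gives 678 nM as a measured number
- Compound 3 `Nc1ccccc1NC(=O)c1ccc(CCc2ccccc2NS(=O)(=O)c2ccc(Br)cc2)cc1` gives 124 nM as a measured number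

Of the two actual numbers, the lower belongs to compound 3, and the gap up to compound 2 lies beyond the usual scatter. The value for compound 1 is only a limit.

Compound 4 `Nc1ccccc1NC(=O)c1ccc(CCc2ccccc2)cc1` follows from compound 3 by a single change: hydrogen in place of ((4-bromophenyl)sulfonyl)amino on an aromatic carbon (hydrogen in place of ((4-bromophenyl)sulfonyl)amino on an aromatic carbon, ortho to a large group). For the measured compounds named here, no pair of measured compounds differs in one place, so the size of this step cannot be read from a direct precedent. Every measured compound still carries a sulfonylamino group, and compound 4 would be the first without one. The expectation is therefore a rise in the number beyond the scatter, meaning weaker inhibition of growth, starting from the 124 nM of compound 3. The expected size is a 24-fold higher number from compound 3 to compound 4 (1.38 log units; beyond the scatter) in this assay as an estimate. For compound 4 the estimated value is 3000 nM with an expected range from 700 nM to 10000 nM in this estimate.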

Compound 4, concentration for 50% growth inhibition: > 10000 nM
Compound 4: only a limit was reported; the forecaster's own chance of this, stated with the estimate: 25%; middle value at least 3.3-fold (0.52 log units) away from the limit.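

In this assay, for the compounds shown here, hydrogen in place of ((4-bromophenyl)sulfonyl)amino on an aromatic carbon, ortho to a large group, gives an at least 80-fold higher number from compound 3 to compound 4 (1.90 log units; beyond the scatter), the first step that sizes a single change at this place. Hydrogen in place of ((4-methoxyphenyl)sulfonyl)amino gives an at least 14-fold higher number from compound 2 to compound 4 (1.16 log units; beyond the scatter), so both compounds with a measured number lose much of their growth inhibition when the sulfonylamino group is gone, while the step that starts at compound 1 cannot be read, as both of its ends are limits. Both readable steps give only a lower bound on the size of the change, since the value of compound 4 is a limit of the assay and not a number: the limit of > 10000 nM in this assay, at which 2 of the 4 values shown sit.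

The compounds shown leave open which part of the departing group matters, as a plain amine, an acetylamino group or a methylsulfonylamino group at this place would separate the nitrogen from the sulfonyl and from the aromatic ring. They also leave open whether bromine and methoxy on that ring differ in effect, as compound 2 and compound 3 differ in more than one place.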